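The compounds below may be only part of what the source reports. "The series", "measured", "known", "first", "only" and "open" are said of these compounds alone.

So far, a functional assay on MCF7 cells (Homo sapiens) for cytotoxicity, with a stated time of 72 h (a lower number here means a stronger inhibitor, a higher number a weaker inhibitor), has been run on two close relatives. Compound 1 `Cc1cccc(-c2nn3c(c2-c2ccncc2)C(CO)C(C)(C)C3)n1` gives > 100000 nM, which is a limit of the assay and not a number. Compound 2 `Cc1cc(-c2c(-c3cccc(C)n3)nn3c2C(C)C(C)(C)C3)ccn1` gives > 100000 nM, which is also a limit and not a number. Compound 2 therefore stands at the limit of > 100000 nM in this assay, at which 2 of the 2 values shown sit, and no actual potency can be read for it.

Compound 3 `Cc1cccc(-c2nn3c(c2-c2ccnc(Nc4ccc(S(N)(=O)=O)cc4)c2)C(C)C(C)(C)C3)n1` keeps the core of compound 2 and changes one group: (4-sulfamoylphenyl)amino sits in place of methyl on an aromatic carbon, next to the ring nitrogen ((4-sulfamoylphenyl)amino in place of methyl on an aromatic carbon). Among the compounds with values here, this is a large change, and no measured pair shows what a change of this kind does.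

In this assay, a step could only be seen as a move towards stronger inhibition, since compound 2 has only the limit of > 100000 nM. A moderate move in that direction is expected, though compound 3 may well stay at the limit too. The estimated step is an at least 2.0-fold lower number from compound 2 to compound 3 (0.30 log units; that floor lies within the scatter). For compound 3 the expected value is 50000 nM, within an estimated range of 10000 nM to 100000 nM.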

Compound 3, half-maximal inhibitory concentration: 22000 nM
Beside the measured number, compound 3's estimate is 2.3-fold (0.36 log units) above it, within the range that was stated.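

In this assay, within the data shown here, the (4-sulfamoylphenyl)amino group in place of methyl on an aromatic carbon, next to the ring nitrogen, brings the first step that can be read in this small set (an at least 4.5-fold lower number from compound 2 to compound 3 (0.65 log units; beyond the scatter)). This shows that this carbon can carry a far larger group than methyl, one that adds an aromatic ring and hydrogen-bond donors and acceptors, without the cytotoxicity being lost; on the contrary, the number falls. From the compounds shown here alone, the true size of the step remains unknown, and the figure printed is only a floor, because compound 2 has a limit of the assay rather than a number: the limit of > 100000 nM in this assay, at which 2 of the 3 values shown sit.

The change adds several features at once, so the compounds shown do not tell whether the sulfamoyl group, the phenyl ring or the connecting amino nitrogen accounts for the step. Going by these compounds, what a plain amine, a phenylamino group with no sulfamoyl on it, or a carboxylic acid in place of the sulfamoyl would do at this carbon stays open, as does whether a still larger group would lower the number further.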